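The compounds below may be only part of what the source reports. "The series", "measured", "known", "first", "only" and "open" are said of these compounds alone.

Measured so far:
compound 1, `COc1cccc2cc(C(=O)NCCO)c(=N)oc12`: 65%
compound 2, `COc1cccc2cc(C(=O)N[C@@H](CO)C(=O)O)c(=O)oc12`: 24%

In an assay on HEK293 cells for displacement of a labelled ligand from adenosine receptor A2b (Homo sapiens), read by scintillation counting, with a stated time of 30 min, tested at 10 uM (a lower number here means less inhibition, a higher number more inhibition at the concentration tested (going by the name of the read-out)), compound 1 gives the higher of the two numbers shown; compound 2 sits well lower, a gap beyond the usual scatter. These two structures differ in more than one place, so only their values can be set side by side. Compound 3, `CCC(CO)NC(=O)c1cc2cccc(OC)c2oc1=N`, has not yet been measured. It differs from compound 1 by ethyl in place of hydrogen on a saturated chain carbon bound to an amide-type nitrogen and a saturated chain carbon. For the measured compounds named here, no single-change step between measured compounds is available to guide the expectation, so only a modest step is expected, a number 10 percentage points lower from compound 1 to compound 3 (within the scatter), downward or none beyond the scatter. Compound 3 is therefore estimated at 55%, within 30% to 75%.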

Compound 3, a percentage reported as inhibition, at one concentration (the size of the read-out at that concentration, not a potency): 39%
The estimate for compound 3 lay 16 percentage points above the measured number; the range from low to high includes it.
By their numbers in this assay, from the lowest: compound 2; then compound 3; then compound 1.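

In this assay, ethyl in place of hydrogen on the saturated chain carbon bound to the amide-type nitrogen gives a number 26 percentage points lower from compound 1 to compound 3 (beyond the scatter) and so provides the first single-change reading among these compounds. At this position, the added ethyl costs inhibition at the concentration tested. No measured evidence here explains the loss.

Going by these compounds, whether methyl or an amine at the same carbon would give a smaller loss, a larger one or none remains open. A single step cannot show whether other groups there would follow the same trend.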